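The source may hold more compounds than are shown below. What is called first, only, known or untested is meant among the compounds shown, and "the series" means these compounds.

Compound 1 `COc1ccc(C(=O)/C=C/c2cc(-c3cc(OC)c(OC)c(OC)c3)n[nH]2)cc1OC` and compound 2 `COc1cc(-c2cc(/C=C/C(=O)c3ccc(F)c(F)c3)[nH]n2)cc(OC)c1OC` share one core and differ only in the ring attached to the carbonyl carbon. In a functional assay on HT-29 cells (Homo sapiens) for inhibition, read by sulforhodamine B assay, with a stated time of 48 h (a lower number here means a stronger inhibitor of growth, a higher number a weaker inhibitor of growth), compound 1 gives 3050 nM, and compound 2 gives 6460 nM. Among the compounds with values here, of the two numbers so far, compound 1 has the lower one, and the single step known, a 2.1-fold higher number from compound 1 to compound 2 (0.33 log units; beyond the scatter), comes from putting 3,4-difluorophenyl in place of 3,4-dimethoxyphenyl on the carbonyl carbon.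

Compound 3 `COc1cc(C(=O)/C=C/c2cc(-c3cc(OC)c(OC)c(OC)c3)n[nH]2)cc(OC)c1OC` keeps the ring of compound 1 but carries methoxy in place of hydrogen on an aromatic carbon. Within the data shown here, no measured step adds a group to this ring; the one step seen, a 2.1-fold higher number from compound 1 to compound 2 (0.33 log units; beyond the scatter), swaps the two methoxy groups for fluorines and shows only a modest loss. A change of this kind therefore gives no strong reason to expect a step beyond the scatter in this assay, and a 1.2-fold lower number from compound 1 to compound 3 (0.09 log units; within the scatter) is the expected size. For compound 3 the estimated value in this assay is 2500 nM, with a likely range from 900 nM to 7000 nM.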

Compound 3, concentration for total growth inhibition: 3370 nM
Beside the measured number, compound 3's estimate is 1.3-fold (0.13 log units) below it; the measured number falls inside the stated range.
By their numbers in this assay, from the lowest: compounds 1, 3 and 2 (each within the scatter of the next, the first and the last beyond it).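

Putting methoxy on this aromatic carbon, ortho to a methoxy group, gives a 1.1-fold higher number from compound 1 to compound 3 (0.04 log units; within the scatter) in this assay, so the ring on the carbonyl carbon accepts this extra group at this position without a step that can be read. The earlier step swapped the groups already on this ring for fluorines, whereas this one adds a group to it, and here the two numbers stay within the scatter of each other. No measurement at hand explains this result.
Still open, on these data alone, is whether a different group at this same position, such as an amine, a carboxylic acid or a longer chain like ethoxy, would move the number beyond the scatter. As far as these compounds go, what a change on the other methoxy-bearing ring would do also stays open.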